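The source may hold more compounds than are shown below. What is called first, only, known or untested is meant among the compounds shown, and "the series" means these compounds.

Measured in an ADME assay on microsomes from liver (Homo sapiens) for pharmacokinetics, read by LC-MS, using NADPH, with a stated time of 45 min, tested at 1 uM; on this read-out higher numbers stand for fast clearance and lower numbers for slow clearance:
- compound 1 `COc1cc(OCc2ccnc(N)n2)cc2sc(N[C@H]3CCCC[C@@H]3O)nc12`: 9.5 mL/min/kg
- compound 2 `COc1cc(OCc2ccnc(N)n2)c(Cl)c2sc(N[C@H]3CCCC[C@@H]3O)nc12`: 33 mL/min/kg

Of these two compounds, compound 1 has the lower number at 9.5 mL/min/kg, so it is the more slowly cleared of the pair. The next compound to be tested is compound 3 `CNC(=O)Nc1nccc(COc2cc(OC)c3nc(N[C@H]4CCCC[C@@H]4O)sc3c2)n1`. Its change from compound 1 is methylcarbamoyl in place of hydrogen on a nitrogen on an aromatic ring, or amino to (methylcarbamoyl)amino when cut one bond further out.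

Going by the values given here, only one measured step can serve as a guide in this assay. That step is a 3.5-fold higher number from compound 1 to compound 2 (0.54 log units; beyond the scatter), and it came from chloro in place of hydrogen on an aromatic carbon. It involves a different group at a different place, so it offers only a rough sense of how far a single addition can move this read-out. With so little evidence, a small rise is expected, smaller than the step to compound 2 and possibly lost in the usual scatter. The expected change is a 1.5-fold higher number from compound 1 to compound 3 (0.17 log units; within the scatter). For compound 3 the estimated clearance is 14 mL/min/kg, with an expected range from 6 mL/min/kg to 35 mL/min/kg.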

Compound 3, clearance: 23 mL/min/kg
The estimate for compound 3 lay 1.6-fold (0.22 log units) below the measured number; low and high end bracket the measured number.
By their numbers in this assay, from the lowest: compound 1; then compounds 3 and 2 (each within the scatter of the next).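

In this assay, the change from amino to (methylcarbamoyl)amino gives a 2.4-fold higher number from compound 1 to compound 3 (0.38 log units; beyond the scatter) on this clearance read-out, so the nitrogen carrying this group is a place where a single addition can shift the number. Going by these compounds alone, until now, the only step available was chloro in place of hydrogen on an aromatic carbon, and it said nothing about this nitrogen. Now both single changes made to compound 1 end in a higher number, with each step beyond the usual scatter, so among these three compounds, compound 1 stays the most slowly cleared at 9.5 mL/min/kg in this assay.

Two compounds leave open whether a different group on this nitrogen, such as acetyl or a plain methyl, would bring the number back towards that of compound 1 or push it higher, and whether a longer chain in place of the methyl at the end of methylcarbamoyl would do the same. Why clearance rises with this change also stays open, since nothing measured here bears on the reason.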